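Methoxy for Sulfamoyl on a Shared Core

The source may report more compounds than this note shows. Statements on the series, on what has been measured and on what is new or still open speak of the compounds shown alone.

Compound 1, `Cc1cnc(Nc2ccc(C(C)C)cc2)nc1Nc1nc2ccccc2s1`, in a functional assay on PC-3 cells (Homo sapiens) for antiproliferative activity, read by MTT assay, with a stated time of 48 h (on this read-out higher numbers stand for weaker inhibition and lower numbers for stronger inhibition), gives compound 1 only a limit, > 50000 nM.
Compound 2, `Cc1cnc(Nc2ccc(S(N)(=O)=O)cc2)nc1Nc1nc2ccccc2s1`, gives in this assay only a limit, > 50000 nM.
Compound 3, `COc1ccc2nc(Nc3nc(Nc4ccc(S(N)(=O)=O)cc4)ncc3C)sc2c1`, gives in this assay only a limit, > 50000 nM.

Compound 2 therefore stands at the limit of this assay, and so does every other compound measured here: the limit of > 50000 nM in this assay, at which 3 of the 3 values shown sit. Compound 4, `COc1ccc(Nc2ncc(C)c(Nc3nc4ccccc4s3)n2)cc1`, differs from compound 2 by methoxy in place of sulfamoyl on an aromatic carbon. Among the compounds with values here, two measured steps bear on it. The step that the two limits leave unreadable from compound 1 to compound 2 concerns the same aromatic carbon of compound 2 at which the sulfamoyl is now exchanged, and the step that the two limits leave unreadable from compound 2 to compound 3 introduces a methoxy, though on another ring. Both steps are unreadable, as the two compounds in each pair sit at the limit, so neither the size nor the direction of any step can be drawn from them. Within the data shown here, no step beyond the scatter can be expected on this evidence, and no step within it can be excluded either. Compound 4 is expected to give 50000 nM, with a range from 15000 nM to 150000 nM. Among the measured compounds shown here, the step of a number no higher from compound 2 to compound 4 (the limit leaves the size open) is accordingly expected to be no step at all beyond what the limit already shows.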

Compound 4, half-maximal inhibitory concentration: > 50000 nM
Compound 4 gave a limit, no number; the forecaster's own chance of this, stated with the estimate: 75%; the middle value lies on the limit itself.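

In this assay compound 4 gives only a limit, > 50000 nM. Within the data shown here, no step from compound 1 or compound 2 to compound 4 can be read, since all of them sit at one limit: the limit of > 50000 nM in this assay, at which 4 of the 4 values shown sit.

The compounds shown leave open whether any exchange on the shared core changes the read-out in this assay; none of them yields a number.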